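A few compounds are considered here, and "the series" means these few. Any claim that something is new, unique, unknown or untested is made for them only; others in the source may bear on it.

Compound 1 `CC(=O)Nc1cnc2[nH]c(=O)n([C@H]3CC[C@@H](C(C)C)CC3)c(=O)c2c1`: 16000 nM
Compound 2 `CC[C@H]1CC[C@H](n2c(=O)[nH]c3ncc(NC(C)=O)cc3c2=O)CC1`: 215000 nM
Compound 3 `CC[C@H]1CC[C@@H](n2c(=O)[nH]c3ncc(NC(C)=O)cc3c2=O)CC1`: 48000 nM

In an ADME assay on L6 cells (Rattus norvegicus) for cytotoxicity, read by resazurin assay, with a stated time of 70 h (on this read-out lower numbers stand for an effect already at smaller amounts and higher numbers for an effect only at larger amounts of compound), compound 3 at 48000 nM is the second highest of the three numbers, above compound 1 and below compound 2. Compound 4 `CC(=O)Nc1cnc2[nH]c(=O)n(CCC3CCCCC3)c(=O)c2c1` keeps the same atoms but joins them differently: 2-cyclohexylethyl in place of 4-ethylcyclohexyl on an aromatic nitrogen. Within the data shown here, no measured step makes this exact change, but two alter the same group: a 3.0-fold higher number from compound 1 to compound 3 (0.48 log units; beyond the scatter), and a 4.5-fold lower number from compound 2 to compound 3 (0.65 log units; beyond the scatter). Both are modest, and the second comes with the fact that compounds 2 and 3 differ only in the configuration as drawn. They point in no clear direction for compound 4, so no shift beyond the scatter is expected, and the estimate is a 1.2-fold lower number from compound 3 to compound 4 (0.08 log units; within the scatter). For compound 4 the expected value is 40000 nM, with an estimated range of 13000 nM to 140000 nM.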

Compound 4, half-maximal effective concentration in the L6 assay: 130000 nM
Estimate against measurement, compound 4: 3.3-fold (0.51 log units) below; the measured number falls inside the stated range.
By their numbers in the L6 assay, from the lowest: compound 1; then compound 3; then compounds 4 and 2 (each within the scatter of the next).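

In the L6 assay, placing 2-cyclohexylethyl on the aromatic nitrogen gives a 2.7-fold higher number from compound 3 to compound 4 (0.43 log units; beyond the scatter), so the same carbon atoms, joined differently, can move this read-out. Against the other configuration, in the L6 assay the same swap gives a 1.7-fold lower number from compound 2 to compound 4 (0.22 log units; within the scatter), so the size of the step depends on which drawn form of 4-ethylcyclohexyl it starts from: the fact that compounds 2 and 3 differ only in the configuration as drawn

In a physicochemical assay for solubility, read by nephelometry, measured as kinetic solubility (on this read-out higher numbers stand for higher solubility and lower numbers for lower solubility), this change also registers, with compound 3 at 48000 nM and compound 4 at 97000 nM: the measured solubility of compound 3, 48000 nM, and of compound 4, 97000 nM, a 2.0-fold higher number (0.31 log units; beyond the scatter)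

Every group shown on this nitrogen contains only carbon. As far as these compounds go, how a chain ending in an amine or a carboxylic acid would behave here stays open.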